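The source may hold more compounds than are shown below. What is called first, only, known or untested is meant among the compounds shown, and "the series" means these compounds.

Going by the values given here, in a functional assay on HepG2 cells (Homo sapiens) for inhibition, read by MTT assay, with a stated time of 48 h (on this read-out higher numbers stand for weaker inhibition and lower numbers for stronger inhibition), compound 2 (`CCOC(=O)C1=C(NN=C(C#N)C#N)Nc2[nH]nc(C)c2C1c1ccc(N(C)C)cc1`) gives 13700 nM and holds the lowest of the three numbers so far, ahead of compound 3 (`CCOC(=O)C1=C(N/C=N/c2ccc(C)cc2)Nc2[nH]nc(C)c2C1c1ccc(N(C)C)cc1`) at 44400 nM and compound 1 (`CCOC(=O)C1=C(N/N=C(\c2ccc([N+](=O)[O-])cc2)N2CCN(c3ccc(F)cc3)CC2)Nc2[nH]nc(C)c2C1c1ccc(N(C)C)cc1`) at 90200 nM on the same scale. The step to compound 4 (`CCOC(=O)C1=C(N)Nc2[nH]nc(C)c2C1c1ccc(N(C)C)cc1`), still unmeasured, is a hydrogen atom in place of a group of 6 heavy atoms (3 carbon, 3 nitrogen; no ring), on an amine nitrogen in the structure. Among the compounds with values here, one measured step replaces the same group, a 3.2-fold higher number from compound 2 to compound 3 (0.51 log units; beyond the scatter) and it points upward, although no measured compound carries a bare hydrogen there. In this assay an estimated step of similar size and the same upward direction is therefore expected (a 2.6-fold higher number from compound 2 to compound 4 (0.41 log units; beyond the scatter)). The estimated value for compound 4 is 35000 nM (expected range 11000 nM to 110000 nM).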

Compound 4, half-maximal inhibitory concentration: 4240 nM
Beside the measured number, compound 4's estimate is 8.3-fold (0.92 log units) above it, outside the stated range (below it).
By their numbers in this assay, from the lowest: compound 4; then compound 2; then compound 3; then compound 1.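

In this assay, the step of a 3.2-fold lower number from compound 2 to compound 4 (0.51 log units; beyond the scatter) and the step of a 10-fold lower number from compound 3 to compound 4 (1.02 log units; beyond the scatter) both go downward when a hydrogen atom takes the place of the group on this amine nitrogen. Until now, the numbers only compared substituted compounds; here, the unsubstituted amine gives a lower number than either the six-atom group or the nine-atom aromatic group. Nothing available explains this difference. The compounds shown leave open whether a small group on this nitrogen, such as methyl or acetyl, would stay near compound 4 or rise towards compound 2.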